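Swapping chloro for methoxy on a sulfonamide compound

The compounds below may be only part of what the source reports. "The series", "measured", "known", "first", "only" and "open" are said of these compounds alone.

Among the measured compounds shown here, in a functional assay on SK-OV-3 cells (Homo sapiens) for antiproliferative activity, read by sulforhodamine B assay, with a stated time of 48 h (a lower number here means a stronger inhibitor, a higher number a weaker inhibitor), compound 1 (`Cc1cc(C)cc(NS(=O)(=O)c2ccc(N3CCNC3=O)cc2)c1`) gives 190 nM and compound 2 (`O=C1NCCN1c1ccc(S(=O)(=O)Nc2cccc(Cl)c2)cc1`) gives 70 nM as the lower of the two numbers measured so far. Compound 3 (`COc1cccc(NS(=O)(=O)c2ccc(N3CCNC3=O)cc2)c1`) keeps the shared core of compound 2 and differs at one place: methoxy in place of chloro on an aromatic carbon. Here methoxy stands in place of chloro on an aromatic carbon, meta to a large group. For the measured compounds named here, one measured step bears on this, a 2.7-fold lower number from compound 1 to compound 2 (0.43 log units; beyond the scatter), with 3-chlorophenyl in place of 3,5-dimethylphenyl, though it does not test methoxy itself. On the size of that modest step alone, a similar or smaller move towards a higher number is expected in this assay for the new compound. The expected change is a 1.7-fold higher number from compound 2 to compound 3 (0.23 log units; within the scatter) as a modest one. For compound 3 the estimated value is 120 nM with an expected range from 45 nM to 320 nM as the likely span.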

Compound 3, half-maximal inhibitory concentration: 240 nM
Compound 3: the middle estimate sits 2.0-fold (0.30 log units) below what was measured, within the range that was stated.
By their numbers in this assay, from the lowest: compound 2; then compounds 1 and 3 (each within the scatter of the next).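

In this assay, methoxy in place of chloro gives a 3.4-fold higher number from compound 2 to compound 3 (0.54 log units; beyond the scatter), so this position does not treat the two groups alike, and the low number of compound 2 is tied to its 3-chlorophenyl group rather than to any single substituent at this place. The other new comparison gives a 1.3-fold higher number from compound 1 to compound 3 (0.10 log units; within the scatter), which puts 3-methoxyphenyl and 3,5-dimethylphenyl level with each other and leaves compound 2 alone with the lowest number of the three. No measurement at hand accounts for the gap between chloro and methoxy.

On these data alone, whether the gain is particular to chlorine or would also appear with fluoro, bromo or trifluoromethyl at this place stays open. So does how an amine, a hydroxy group or a longer chain such as ethoxy would read here.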